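From naphthalen-1-yl to 4-cyanophenyl at the assay limit

The source may report more compounds than this note shows. Statements on the series, on what has been measured and on what is new or still open speak of the compounds shown alone.

Measured in a functional assay on HL-60 cells (Homo sapiens), read by calcium flux; a lower number here means that less compound is needed, a higher number that more compound is needed for the effect:
- Compound 1 `COc1cc(Cc2cc(C)nn(CC(=O)Nc3ccc(Br)cc3)c2=O)cc(OC)c1`: > 50000 nM (a limit)
- Compound 2 `Cc1cc(Cc2cccc3ccccc23)c(=O)n(CC(=O)Nc2ccc(Br)cc2)n1`: > 50000 nM (a limit)

Compound 2 gives > 50000 nM, which is a limit of the assay and not a number. Among the measured compounds shown here, the same holds across the series so far: the limit of > 50000 nM in this assay, at which 2 of the 2 values shown sit.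

Compound 3 `Cc1cc(Cc2ccc(C#N)cc2)c(=O)n(CC(=O)Nc2ccc(Br)cc2)n1` has 4-cyanophenyl in place of naphthalen-1-yl on a saturated chain carbon bound to an aromatic carbon.

For the measured compounds named here, the only measured step that bears on this is a swap at the same place, a step that the two limits leave unreadable from compound 1 to compound 2. Going by the values given here, it offers no size to carry over, so no firm step can be predicted. The likeliest outcome is that compound 3 also stays at the limit in this assay, and any real number that appears would be a smaller one. The estimated step is an at least 1.2-fold lower number from compound 2 to compound 3 (0.09 log units; that floor lies within the scatter). For compound 3 the expected value is 40000 nM, with an estimated range of 6000 nM to 50000 nM.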

Compound 3, half-maximal effective concentration: > 50000 nM
Compound 3 was reported as a limit; the forecaster's own chance of this, stated with the estimate: 65%; at least 1.2-fold (0.09 log units) between middle value and limit.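

In this assay compound 3 gives > 50000 nM as a limit and not a number. The steps to compound 3 from compound 1 and compound 2 therefore cannot be read, and all three compounds sit at the same limit: the limit of > 50000 nM in this assay, at which 3 of the 3 values shown sit.

The compounds shown leave open whether 3,5-dimethoxyphenyl, naphthalen-1-yl and 4-cyanophenyl differ at all in this read-out.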